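Carboxyindole to tetrazolylphenyl on the ring-amine methylene

The source may hold more compounds than are shown below. What is called first, only, known or untested is meant among the compounds shown, and "the series" means these compounds.

Compound 1 `OC[C@@H](O[C@H]1CCCN(Cc2ncc[nH]2)[C@H]1c1ccccc1)c1cc(Cl)cc(Cl)c1`: 7000 nM
Compound 2 `O=C(O)c1ccc2c(CN3CCC[C@H](O[C@H](CO)c4cc(Cl)cc(Cl)c4)[C@@H]3c3ccccc3)c[nH]c2c1`: 22000 nM

In an assay on isolated protein for activation of cGMP-dependent protein kinase 1 (Homo sapiens), read by ADP-Glo, with stated times of 120 min and 40 min (a higher number here means that more compound is needed for the effect, a lower number that less compound is needed), compound 2 gives the higher of the two numbers, with compound 1 nearest at a 3.1-fold higher number from compound 1 to compound 2 (0.50 log units; beyond the scatter). Compound 3 `OC[C@@H](O[C@H]1CCCN(Cc2ccc(-c3nn[nH]n3)cc2)[C@H]1c1ccccc1)c1cc(Cl)cc(Cl)c1` differs from compound 2 by 4-(2H-tetrazol-5-yl)phenyl in place of 6-carboxy-1H-indol-3-yl on a saturated chain carbon bound to an amine nitrogen in a ring. Among the compounds with values here, the only step that touches this position is a 3.1-fold higher number from compound 1 to compound 2 (0.50 log units; beyond the scatter), a modest rise, and the tetrazolylphenyl group has no measured neighbor of its own. The expectation is therefore a small move back toward compound 1, with a 1.5-fold lower number from compound 2 to compound 3 (0.17 log units; within the scatter) estimated. Compound 3 is expected to give about 15000 nM, within 5000 nM to 45000 nM.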

Compound 3, half-maximal effective concentration: 131000 nM
Estimate against measurement, compound 3: 8.7-fold (0.94 log units) below; the whole stated range lies below it.
By their numbers in this assay, from the lowest: compound 1; then compound 2; then compound 3.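

In this assay the 4-(2H-tetrazol-5-yl)phenyl group brings a 6.0-fold higher number from compound 2 to compound 3 (0.77 log units; beyond the scatter) on top of the earlier rise, and set against 1H-imidazol-2-yl the change amounts to a 19-fold higher number from compound 1 to compound 3 (1.27 log units; beyond the scatter) at the same place. The group on this carbon thus separates all three compounds, and heavy atoms do not order them: the entering group has fewer heavy atoms than 6-carboxy-1H-indol-3-yl, yet compound 3 gives the highest number. Nothing measured here explains the rise. Open, on these data alone, is whether a carboxylic acid on the phenyl ring in place of the tetrazole, or an unsubstituted phenyl, would bring the number back toward that of compound 1.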